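The source may hold more compounds than are shown below. What is called first, only, known or untested is meant among the compounds shown, and "the series" means these compounds.

Measured so far in a functional assay on HCT-116 cells (Homo sapiens) for cytotoxicity, read by MTT assay, with a stated time of 72 h; a lower number here means a stronger inhibitor, a higher number a weaker inhibitor:
- compound 1 `O=C(NCc1ccc(F)cc1)c1nc(Br)c2cccnc2c1N1CCNCC1`: > 10000 nM (a limit)
- compound 2 `O=C(NCc1ccc(F)cc1)c1nc(Br)c2cccnc2c1NCc1ccccc1`: > 20000 nM (a limit)

Compound 2 has no readable number, as its > 20000 nM is a limit. The next compound is compound 3 `Cc1ccc(S(=O)(=O)Oc2c(C(=O)NCc3ccc(F)cc3)nc(Br)c3cccnc23)cc1`, and the change is ((4-methylphenyl)sulfonyl)oxy in place of benzylamino on an aromatic carbon. Benzylamino leaves and ((4-methylphenyl)sulfonyl)oxy enters on the same aromatic carbon, para to a bromo group.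

Going by the values given here, the only measured step at this carbon is a step that the two limits leave unreadable from compound 1 to compound 2. Among the compounds with values here, it gives no size to carry over, and no compound carrying ((4-methylphenyl)sulfonyl)oxy has been measured. The expected step in this assay therefore has no firm direction or size. The expectation rests on compound 2 at > 20000 nM, and another weak result, quite possibly a limit again, is expected.

The estimated step is an at least 1.6-fold lower number from compound 2 to compound 3 (0.22 log units; that floor lies within the scatter). The estimated value for compound 3 is 12000 nM. The expected range for compound 3 runs from 2500 nM to 30000 nM.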

Compound 3, half-maximal inhibitory concentration: > 20000 nM
Compound 3 ended at the assay's limit; the forecaster's own chance of this, stated with the estimate: 55%; at least 1.6-fold (0.22 log units) between middle value and limit.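

In this assay compound 3 gives > 20000 nM, a limit. Going by these compounds alone, the values of compound 1 and compound 2 are limits too, so no step among compound 1, compound 2 and compound 3 can be read. Open, going by these compounds, is whether any group on this aromatic carbon, para to a bromo group, gives a readable value in this assay, and how piperazin-1-yl, benzylamino and ((4-methylphenyl)sulfonyl)oxy rank there.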